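This account rests on a few compounds, and the source may have more. Where it says the series, first, only, none or still open, it means among the compounds named here.

Measured compounds:
- compound 1, `O=C(Cc1cccnc1)c1cc2ccccc2[nH]1`: 65000 nM
- compound 2, `O=C(Cc1cccnc1)c1cc2cc(Br)ccc2[nH]1`: 18000 nM
- compound 3, `O=C(Cc1cccnc1)c1cc2cc([N+](=O)[O-])ccc2[nH]1`: "not active" (no number reported) (no number reported)

The shared core of compound 1 carries a pyridinylmethyl ketone on the indole-type ring system shown. Within the data shown here, in an assay on isolated protein for inhibition of Indoleamine 2,3-dioxygenase 1 (Homo sapiens), read by spectrophotometry (a higher number here means a weaker inhibitor, a lower number a stronger inhibitor), compound 1 gives 65000 nM, the highest of the two numbers available; compound 2 sits nearest, and the one-place step a 3.6-fold lower number from compound 1 to compound 2 (0.56 log units; beyond the scatter) is the only measured step in the set. Compound 3 returns "not active" (no number reported) without a number.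

Compound 4, `O=C(Cc1cccnc1)c1cc2ccc(F)cc2[nH]1`, differs from compound 1 by fluoro in place of hydrogen on an aromatic carbon. The measured step that bears on it is a 3.6-fold lower number from compound 1 to compound 2 (0.56 log units; beyond the scatter), a modest gain from a halogen on the six-membered ring of the core; however, it concerns a different halogen and a different ring carbon, so it only loosely transfers. Compound 3 shows that not every substituent on that ring is tolerated. On this basis a small step in this assay is expected, leaning toward a lower number but possibly within the scatter.

For compound 4 the expected value in this assay is 45000 nM, with a range of 15000 nM to 110000 nM, meaning an expected step of a 1.4-fold lower number from compound 1 to compound 4 (0.16 log units; within the scatter).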

Compound 4, half-maximal inhibitory concentration: 43000 nM
For compound 4 the middle estimate is 1.0-fold (0.02 log units) above the measured one; low and high end bracket the measured number.
By their numbers in this assay, from the lowest: compound 2; then compounds 4 and 1 (each within the scatter of the next).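

In this assay the new step, a 1.5-fold lower number from compound 1 to compound 4 (0.18 log units; within the scatter), shows that fluoro in place of hydrogen on this aromatic carbon, meta to a fused ring and para to a fused ring, leaves the number of compound 1 within the scatter. The six-membered ring of the shared core now carries one halogen step beyond the scatter, a 3.6-fold lower number from compound 1 to compound 2 (0.56 log units; beyond the scatter), and one within it, so a halogen on this ring does not by itself give a step beyond the scatter. Nothing available accounts for the size of the fluoro step.

Open, going by these compounds, is whether a larger halogen such as chloro or bromo on this same aromatic carbon would move the number beyond the scatter, which would separate the effect of the halogen from that of the ring carbon. Also open, on these data alone, is how groups of another kind, such as methoxy, an amine or a carboxylic acid, behave on this carbon, given that compound 3 on the same ring returns no number at all.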